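Swapping one ring group on a shared core

This account rests on a few compounds, and the source may have more. Where it says the series, first, only, none or still open, it means among the compounds named here.

Measured in a physicochemical assay for lipophilicity, using the shake flask method (a lower number here means a more polar compound, a higher number a more lipophilic compound), so far:
- compound 1 `CC(C)Oc1cc(Oc2ccc(S(C)(=O)=O)cc2)cc(-c2cccc(=O)[nH]2)c1` gives 2.82
- compound 2 `CC(C)Oc1cc(Oc2ccc(S(C)(=O)=O)cc2)cc(-c2ccnc(=O)[nH]2)c1` gives "not determined" (no result reported)

For the measured compounds named here, compound 1 holds the only number here, so there is no other measured compound to rank it against. In compound 3 `Cc1cnc(-c2cc(Oc3ccc(S(C)(=O)=O)cc3)cc(OC(C)C)c2)[nH]c1=O` the shared core stays and one group changes (a group of 8 heavy atoms (5 carbon, 2 nitrogen, 1 oxygen; one six-membered aromatic ring with 2 hetero atoms) in place of a group of 7 heavy atoms (5 carbon, 1 nitrogen, 1 oxygen; one six-membered aromatic ring with 1 hetero atom), on an aromatic carbon). Going by the values given here, no measured pair shows this swap, so the data offer no direct guide to its size. A small fall in this assay is expected, and the estimated step of a number 0.32 log units lower from compound 1 to compound 3 (beyond the scatter) is only a rough judgement. Compound 3 is estimated at 2.5 with an expected range from 2 to 3 around that figure.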

Compound 3, distribution coefficient: 2.68
Estimate against measurement, compound 3: 0.18 log units below, and the stated range covers the measured number.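

In this assay, placing the group of 8 heavy atoms with 2 hydrogen-bond acceptors on this aromatic carbon, in place of the group of 7 heavy atoms with 1 hydrogen-bond acceptor, gives a number 0.14 log units lower from compound 1 to compound 3 (within the scatter) and so leaves the reading effectively unchanged. At this position, then, the larger ring group with 2 hetero atoms can replace the ring group with 1 hetero atom without a measurable shift in this assay. Nothing available explains this result. From the compounds shown here alone, only these two ring groups have numbers here, so what an amine or a carboxylic acid at this place would give remains open.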